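The source may report more compounds than this note shows. Statements on the series, on what has been measured and on what is new or still open speak of the compounds shown alone.

Cytotoxicity toward human cells was measured in an ADME assay on HEK293 cells (Homo sapiens) for cytotoxicity, with a stated time of 72 h; a higher number here means that more compound is needed for the effect, a lower number that less compound is needed. Of the compounds shown here, three built on one shared core have been tested there, and a fourth is still to come.

Compound 1, with the structure `C=C[C@@](C)(/C=C/c1ccc(O)cc1)CC/C=C/C(=O)OCC`, gives > 36600 nM in this assay, and that figure is a limit of the assay rather than a number. Compound 2, `C=C[C@@](C)(/C=C/c1ccc(O)cc1)CC/C=C/C(=O)OCc1ccccc1`, differs from compound 1 by phenyl in place of methyl on a saturated chain carbon bound to an oxygen next to a carbonyl group. In this assay compound 2 gives > 36600 nM, again a limit. Because both ends are limits, the step that the two limits leave unreadable from compound 1 to compound 2 cannot be read.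

Compound 3, `C=C[C@@](C)(/C=C/c1ccc(O)cc1)CC/C=C(C)/C=C/C(=O)OCC`, carries a core that differs from the core of compound 1 in a way that is not broken down here. In this assay compound 3 gives > 36600 nM, which is once more a limit.

Compound 4, `C=C[C@@](C)(/C=C/c1ccc(O)cc1)CC/C=C(C)/C=C/C(=O)OCc1ccccc1`, is not yet measured. It stands to compound 3 exactly as compound 2 stands to compound 1: the change is phenyl in place of methyl on a saturated chain carbon bound to an oxygen next to a carbonyl group, the same change at the same place. What is known so far is summed up by the limit of > 36600 nM in this assay, at which 3 of the 3 values shown sit, since all three measured compounds sit at that limit.

With nothing measurable to build on, the step of a number no higher from compound 3 to compound 4 (the limit leaves the size open) is expected to be flat, resting on compound 3 and its value > 36600 nM. Compound 4 is therefore estimated to give 36600 nM in this assay, with a range from 15000 nM to 90000 nM, and the reading will most likely again be a limit.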

Compound 4, half-maximal effective concentration: > 36600 nM
Compound 4: a limit, no number; the forecaster's own chance of this, stated with the estimate: 85%; the middle value sits exactly at the limit.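

Within the data shown here, compound 3 and compound 4 both give a limit rather than a number in this assay, so the step between them cannot be read, any more than the one between compound 1 and compound 2. The compounds shown leave open how much of each would be needed for the effect, and whether phenyl in place of methyl changes that amount at all.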